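Vero cytotoxicity notes: three measured analogues, one pending

The source may report more compounds than this note shows. Statements on the series, on what has been measured and on what is new or still open speak of the compounds shown alone.

Compound 1 `COc1ccc(C(=O)Nc2cc3nc(C4CCCCC4)[nH]c3cc2N(C)C)cc1`: > 100 ug/mL
Compound 2 `COc1ccc(C(=O)Nc2cc3nc(C4CCCCC4)[nH]c3cc2N2CCCC2)cc1`: > 100 ug/mL
Compound 3 `COCCOC(=O)Nc1cc2nc(C3CCCCC3)[nH]c2cc1N1CCCC1`: > 100 ug/mL

In an ADME assay on Vero cells (Chlorocebus sabaeus) for cytotoxicity, read by resazurin assay, with a stated time of 3 days (a lower number here means a stronger inhibitor, a higher number a weaker inhibitor), compound 1 gives > 100 ug/mL, which is a limit of the assay and not a number. Compound 2 gives only a limit as well, > 100 ug/mL. Compound 3 again gives only a limit, > 100 ug/mL. Compound 1 therefore stands nowhere in particular on the numbers shown: all three values sit at the same limit, as summarised by the limit of > 100 ug/mL in this assay, at which 3 of the 3 values shown sit, and no compound can be placed above or below another.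

The two measured steps are a step that the two limits leave unreadable from compound 1 to compound 2 and a step that the two limits leave unreadable from compound 2 to compound 3. Neither can be read in size or direction, since both ends of each step are limits.

Compound 4 `CN(C)c1cc2[nH]c(C3CCCCC3)nc2cc1NC(=O)c1ccco1` is the unmeasured analogue. It differs from compound 1 by furan-2-yl in place of 4-methoxyphenyl on a carbonyl carbon. Among the measured compounds shown here, no measured step changes this part of the molecule, so the only guidance is that every change tried so far, whether on the aromatic amine or on the carbonyl carbon, left the value at the limit. The step that the limit leaves unreadable from compound 1 to compound 4 is therefore expected to be none beyond the scatter. Compound 4 is expected to give about 150 ug/mL, within 60 ug/mL to 400 ug/mL, most likely reported again only as a limit.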

Compound 4, half-maximal inhibitory concentration: > 100 ug/mL
Compound 4: only a limit was reported; the forecaster's own chance of this, stated with the estimate: 80%; the middle value does not contradict the limit.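

In this assay compound 4 gives > 100 ug/mL, which is a limit of the assay and not a number. The step from compound 1 to compound 4 cannot be read, since both ends are limits. The compounds shown leave open how compounds 1 to 4 rank against one another, as all share one limit: the limit of > 100 ug/mL in this assay, at which 4 of the 4 values shown sit.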